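Compound 3: a five-membered aromatic ring enters

The source may hold more compounds than are shown below. What is called first, only, known or untested is meant among the compounds shown, and "the series" means these compounds.

Compound 1 (`CCOC(=O)c1c(-c2cccc(-c3ccccc3)c2)[nH]c2cc(OC)c(F)cc2c1=O`) gives > 21500 nM
Compound 2 (`CCOC(=O)c1c(-c2cccc(Oc3c(C)cccc3C)c2)[nH]c2cc(OC)c(F)cc2c1=O`) gives > 21500 nM

In an ADME assay on BJ cells (Homo sapiens) for cytotoxicity, read by luminescence, with a stated time of 72 h (on this read-out lower numbers stand for an effect already at smaller amounts and higher numbers for an effect only at larger amounts of compound), compound 2 gives > 21500 nM as a limit, not a number. Compound 1 gives > 21500 nM as a limit too. Among the measured compounds shown here, the evidence so far is the limit of > 21500 nM in this assay, at which 2 of the 2 values shown sit, and nothing more, and the one measured step is a step that the two limits leave unreadable from compound 1 to compound 2 with no size to lean on. For the measured compounds named here, compound 3 (`CCOC(=O)c1c(-c2cccc(Cc3nc(C)c(C)s3)c2)[nH]c2cc(OC)c(F)cc2c1=O`) comes from compound 2 through a group of 8 heavy atoms (6 carbon, 1 nitrogen, 1 sulfur; one five-membered aromatic ring with 2 hetero atoms) in place of a group of 9 heavy atoms (8 carbon, 1 oxygen; one six-membered aromatic ring of carbon only), on an aromatic carbon as its only change. Since compound 2 sits at the limit > 21500 nM as well, the expected move in this assay is none beyond the scatter, namely a step that the limit leaves unreadable from compound 2 to compound 3 as an estimate. Compound 3 is estimated at 25000 nM with a range from 12000 nM to 50000 nM as expected values, and may again be reported only as a limit.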

Compound 3, half-maximal effective concentration: > 21500 nM
Compound 3 ended at the assay's limit; the forecaster's own chance of this, stated with the estimate: 80%; the middle value is on the limit's open side.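

Compound 3 gives > 21500 nM, a limit and not a number. Among the compounds shown here, no step among compound 1, compound 2 and compound 3 can be read. The compounds shown leave open where any of them would give an actual value in this assay, and whether their differing groups change it.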